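The source may report more compounds than this note shows. Statements on the series, on what has been measured and on what is new or still open speak of the compounds shown alone.

In a functional assay (aorta) with Rattus norvegicus as the target (on this read-out lower numbers stand for an effect already at smaller amounts and higher numbers for an effect only at larger amounts of compound), compound 1 (`O=C(Nc1cc2cc[nH]c(=O)c2cc1Cl)[C@H]1CCCN1`) gives 1120 nM as its reading. Compound 2 (`CC(C)N[C@H](C(=O)Nc1cc2cc[nH]c(=O)c2cc1Cl)C1CCCCC1`) gives 190 nM in the same test. Compound 1 therefore has the higher of the two numbers, and the gap between them lies beyond the usual scatter. Compound 3 (`N[C@H]1CC[C@@H](C(=O)Nc2cc3cc[nH]c(=O)c3cc2Cl)CC1`) has not been measured yet. It keeps the core of compound 1 but carries 4-aminocyclohexyl in place of pyrrolidin-2-yl on a carbonyl carbon, a swap counted as 4-aminocyclohexyl in place of pyrrolidin-2-yl on a carbonyl carbon in full. Neither measured compound carries this new group, so the evidence is thin. Within the data shown here, the only guide is that compound 2, with another group at that carbonyl carbon, reads 190 nM and so lies well under compound 1. The expected change a 2.5-fold lower number from compound 1 to compound 3 (0.40 log units; beyond the scatter) is therefore a moderate fall in the number, with much uncertainty. Compound 3 is estimated at 450 nM with a range from 90 nM to 2200 nM as the likely span.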

Compound 3, half-maximal effective concentration: 180 nM
Compound 3: the middle estimate sits 2.5-fold (0.40 log units) above what was measured, within the range that was stated.
By their numbers in this assay, from the lowest: compounds 3 and 2 (each within the scatter of the next); then compound 1.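

In this assay, the position on a carbonyl carbon whose other neighbour is an amide-type nitrogen proves sensitive to the group it carries: with the rest of compound 1 kept, 4-aminocyclohexyl in place of pyrrolidin-2-yl gives a 6.2-fold lower number from compound 1 to compound 3 (0.79 log units; beyond the scatter). Among these compounds, this is the first change at this position that can be read on its own, and the two groups have the same counts of hydrogen-bond donors and acceptors and no net charge, so those counts do not track the change in the number. Nothing measured here explains why the number falls.

From the compounds shown here alone, it remains open how much depends on the amine of the new ring and how much on the six-membered ring itself. A 4-hydroxycyclohexyl group, with a hydroxyl in place of the amine, or a piperidin-4-yl group, with the nitrogen inside the ring, would help to separate the two.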